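Trifluoromethyl in Place of Fluoro: Compound 3 to Compound 4

The compounds below may be only part of what the source reports. "The series", "measured", "known", "first", "only" and "open" are said of these compounds alone.

Compound 3 `Cc1c(C(=O)Nc2c(F)cc(-c3cccc(F)c3)cc2F)nc2ccc(F)cc2c1C(=O)O` gives 64.3% in a functional assay on A-375 cells (Homo sapiens) for antiproliferative activity, read by MTT assay, with a stated time of 24 h, tested at 100 ug/mL (a lower number here means a weaker effect, a higher number a stronger effect of the compound at the concentration tested), the second highest of the three numbers, with compound 1 `Cc1c(C(=O)Nc2c(F)cc(-c3cccc(F)c3)cc2F)nc2ccc(F)cc2c1O` at 51.3% and compound 2 `Cc1c(C(=O)Nc2c(F)cc(-c3cccc(F)c3)cc2F)nc2ccc(C(F)(F)F)cc2c1O` at 95.2%. Compound 4 `Cc1c(C(=O)Nc2c(F)cc(-c3cccc(F)c3)cc2F)nc2ccc(C(F)(F)F)cc2c1C(=O)O` is not yet measured; it differs from compound 3 as follows: trifluoromethyl in place of fluoro on an aromatic carbon. The same kind of change has been measured once, as a number 43.9 percentage points higher from compound 1 to compound 2 (beyond the scatter), a large gain. The step of a number 13 percentage points higher from compound 1 to compound 3 (beyond the scatter) only sets the starting point. A large upward step is therefore expected for compound 4. Because compound 2 already gives 95.2%, the read-out has little room above that level. The step is expected to be a number 27.7 percentage points higher from compound 3 to compound 4 (beyond the scatter). Compound 4 is estimated at 92%, with a range from 78% to 99%.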

Compound 4, a percentage reported as inhibition, at one concentration (the size of the read-out at that concentration, not a potency): 61.3%
For compound 4 the middle estimate is 30.7 percentage points above the measured one; the whole stated range lies above it.
By their numbers in this assay, from the lowest: compounds 1, 4 and 3 (each within the scatter of the next, the first and the last beyond it); then compound 2.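

In this assay, trifluoromethyl in place of fluoro brings no gain on the core carrying carboxy, a number 3 percentage points lower from compound 3 to compound 4 (within the scatter), and carboxy in place of hydroxy becomes a loss on the core carrying trifluoromethyl, a number 33.9 percentage points lower from compound 2 to compound 4 (beyond the scatter). The effect of this change therefore depends on the group at the other place, and the two changes do not add up: the same change on two cores in this assay, a number 43.9 percentage points higher (beyond the scatter) from compound 1 to compound 2 and a number 3 percentage points lower (within the scatter) from compound 3 to compound 4, 46.9 percentage points apart, beyond the scatter of two such steps

The same dependence appears when the other change is followed: the same change on two cores in this assay, a number 13 percentage points higher (beyond the scatter) from compound 1 to compound 3 and a number 33.9 percentage points lower (beyond the scatter) from compound 2 to compound 4, 46.9 percentage points apart, beyond the scatter of two such steps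

On these data alone, whether an amine in place of carboxy, or chloro in place of trifluoromethyl, would follow compound 2 or compound 4 stays open.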